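Ethoxy in place of cyclopropyl: a half-life in question

The source may report more compounds than this note shows. Statements on the series, on what has been measured and on what is new or still open speak of the compounds shown alone.

Compound 1 `Cc1cc(-c2noc(C3CC3)n2)cc(C)c1OCCCc1cc(C2CC2)no1`: > 2.5 h
Compound 2 `CCc1cc(CCCOc2c(C)cc(-c3noc(C(F)(F)F)n3)cc2C)on1`: > 2.5 h

Within the data shown here, both compounds have been measured in an in vitro ADME assay on microsomes from liver (Simiiformes); a higher number here means that the compound lasts longer, a lower number that the compound disappears faster. Compound 1 gives > 2.5 h, which is a limit of the assay and not a number. Compound 2 gives > 2.5 h, which is also a limit. Compound 1 therefore stands at the limit of > 2.5 h in this assay, at which 2 of the 2 values shown sit.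

The step followed here keeps the core of compound 1 and changes a single group. Compound 3 `CCOc1cc(CCCOc2c(C)cc(-c3noc(C4CC4)n3)cc2C)on1` carries ethoxy in place of cyclopropyl on an aromatic carbon, so that 3-cyclopropyl-1,2-oxazol-5-yl becomes 3-ethoxy-1,2-oxazol-5-yl (ethoxy in place of cyclopropyl on an aromatic carbon). The change sits next to the ring nitrogen.

Among the measured compounds shown here, no measured step is available to size this change in this assay, so any forecast remains loose. The forecast starts from compound 1, whose > 2.5 h is a limit. No shift beyond the scatter is expected, in either direction, and the estimated step is a step that the limit leaves unreadable from compound 1 to compound 3. For compound 3 the expected half-life is 3 h, within an estimated range of 1.5 h to 6 h.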

Compound 3, half-life: > 2.5 h
Compound 3: only a limit was reported; the forecaster's own chance of this, stated with the estimate: 60%; the middle value does not contradict the limit.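

In this assay compound 3 gives > 2.5 h, which is a limit of the assay and not a number. Compound 1 also stands at a limit, so no step can be read between compound 1 and compound 3. The series stands as follows: the limit of > 2.5 h in this assay, at which 3 of the 3 values shown sit. The compounds shown leave open whether ethoxy in place of cyclopropyl changes the half-life at all.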